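Longer chain on the sulfonamide side: compound 3

A few compounds are considered here, and "the series" means these few. Any claim that something is new, unique, unknown or untested is made for them only; others in the source may bear on it.

Measured compounds in a functional assay on A549 cells (Homo sapiens) for inhibition, read by CCK-8 assay, with a stated time of 72 h, tested at 1 uM; on this read-out lower numbers stand for a weaker effect and higher numbers for a stronger effect at the one concentration tested:
Compound 1 `CN(C)C(=O)c1cc2cnc(Nc3ccc(S(=O)(=O)NCCCN=C=S)cc3)nc2n1C1CCCC1` gives 58.9%.
Compound 2 `CN(C)C(=O)c1cc2cnc(Nc3ccc(S(=O)(=O)NCCCCCCN=C=S)cc3)nc2n1C1CCCC1` gives 49.5%.

Of the two numbers, compound 1 holds the larger, but the gap to compound 2, a number 9.4 percentage points lower from compound 1 to compound 2 (within the scatter), lies within the scatter. Compound 3 `CN(C)C(=O)c1cc2cnc(Nc3ccc(S(=O)(=O)NCCCCCCCN=C=S)cc3)nc2n1C1CCCC1` differs from compound 1 by a group of 7 heavy atoms (5 carbon, 1 nitrogen, 1 sulfur; no ring) in place of a group of 3 heavy atoms (1 carbon, 1 nitrogen, 1 sulfur; no ring), on a saturated chain carbon, three bonds along the chain from a sulfonamide nitrogen. Among the measured compounds shown here, the only step that bears on this is the lengthening of the same chain from compound 1 to compound 2, which stayed within the scatter, so no step beyond the scatter is expected here, at most a slight drift downward. For compound 3 the expected step is a number 11.9 percentage points lower from compound 1 to compound 3 (beyond the scatter). Compound 3 is therefore estimated at 47%, between 32% and 62%.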

Compound 3, a percentage reported as inhibition, at one concentration (the size of the read-out at that concentration, not a potency): 32.6%
For compound 3 the middle estimate is 14.4 percentage points above the measured one; measured number inside the range.
By their numbers in this assay, from the lowest: compound 3; then compounds 2 and 1 (each within the scatter of the next).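

In this assay, lengthening this chain now produces a clear loss: a number 26.3 percentage points lower from compound 1 to compound 3 (beyond the scatter), which lies beyond the scatter, unlike the earlier step. The further change of a number 16.9 percentage points lower from compound 2 to compound 3 (beyond the scatter) is also beyond the scatter, so compound 3 stands apart from both shorter-chain compounds, while compound 1 and compound 2 remain unresolved from each other. No available evidence bears on the origin of this loss.

Still open, as far as these compounds go, is whether a longer chain than that of compound 3 continues the trend. Also open, from the compounds shown here alone, is how an amine in place of the nitrogen- and sulfur-bearing group would read out.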